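Fluoro for amino: a matched step repeated in this series

The compounds below may be only part of what the source reports. "The series", "measured", "known", "first", "only" and "open" are said of these compounds alone.

Compound 1 `CC(=O)OC(C)n1cnc2c(Cl)nc(N)nc21` carries amino on its core. In a functional assay on MOLT-4 cells (Homo sapiens) for inhibition (on this read-out lower numbers stand for stronger inhibition and higher numbers for weaker inhibition), compound 1 gives only a limit, > 500000 nM, and the limit of > 500000 nM in this assay, at which 1 of the 3 values shown sits, is all that is known of it. Compound 2 `CC(=O)OC(C)n1cnc2c(Cl)nc(F)nc21` differs by fluoro in place of amino on an aromatic carbon and in this assay compound 2 gives 41000 nM, so the change brings an at least 12-fold lower number from compound 1 to compound 2 (1.08 log units; beyond the scatter).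

Compound 3 `CC(=O)OCCOn1cnc2c(S)nc(N)nc21` sits on a different core; how its core differs from that of compound 1 is not broken down here. In this assay compound 3 gives 8900 nM.

Compound 4 `CC(=O)OCCOn1cnc2c(S)nc(F)nc21` is not yet measured and differs from compound 3 by fluoro in place of amino on an aromatic carbon. This is the same kind of change as from compound 1 to compound 2, not the same: here the place is meta to a sulfanyl group (1 heavy atom) where before it was meta to a chloro group (1 heavy atom).

Beside the earlier step of an at least 12-fold lower number from compound 1 to compound 2 (1.08 log units; beyond the scatter), the step of a 5.9-fold lower number from compound 3 to compound 4 (0.77 log units; beyond the scatter) is expected for compound 4, resting on that one measured pair, whose starting value is a limit. For compound 4 a value of about 1500 nM is estimated in this assay, between 300 nM and 8000 nM.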

Compound 4, half-maximal inhibitory concentration: 35000 nM
Compound 4: middle estimate off by 23-fold (1.37 log units), on the low side; measured number outside the range, above it.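

In this assay fluoro in place of amino gives a 3.9-fold higher number from compound 3 to compound 4 (0.59 log units; beyond the scatter), and this does not match the earlier step on the core of compound 1, so the effect of the change does not transfer directly from one core to the other: the same change on two cores in this assay, an at least 12-fold lower number (1.08 log units; beyond the scatter) from compound 1 to compound 2 and a 3.9-fold higher number (0.59 log units; beyond the scatter) from compound 3 to compound 4, at least 47-fold (1.68 log units) apart, beyond the scatter of two such steps. Compound 1 is known only through a limit of the assay, so the earlier step has a bound and no exact size: the limit of > 500000 nM in this assay, at which 1 of the 4 values shown sits. The two pairs show that the direction of this step is not fixed across these cores, but they do not show which difference between the cores goes with the reversal, and two pairs establish no rule for the series.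

It remains open whether the reversal follows the sulfanyl group in place of chloro or the different chain on the rest of the core, as no compound shown separates the two. A methoxy or dimethylamino group at the same place, between two ring nitrogen atoms, on both cores would test whether the reversal extends beyond fluoro and amino.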